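Replacing trifluoromethyl with hydroxy on compound 3

The source may hold more compounds than are shown below. What is called first, only, known or untested is meant among the compounds shown, and "the series" means these compounds.

Values in an ADME assay on HepG2 cells (Homo sapiens) for cytotoxicity, with a stated time of 72 h; on this read-out higher numbers stand for an effect only at larger amounts of compound and lower numbers for an effect already at smaller amounts:
Compound 1 `Cc1ccc(NC(=O)Nc2cc(C)nc3ccccc23)cc1`: > 25000 nM (a limit)
Compound 2 `Cc1cc(NC(=O)Nc2ccc(N(C)C)cc2)c2ccccc2n1`: > 25000 nM (a limit)
Compound 3 `Cc1cc(NC(=O)Nc2ccc(C(F)(F)F)cc2)c2ccccc2n1`: 23000 nM

For the measured compounds named here, compound 3 carries the only actual number, 23000 nM. Compound 1 gives only a limit, > 25000 nM. Compound 2 also gives only a limit, > 25000 nM. The picture so far is therefore dominated by the limit of > 25000 nM in this assay, at which 2 of the 3 values shown sit.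

Compound 4 `Cc1cc(NC(=O)Nc2ccc(O)cc2)c2ccccc2n1` keeps the shared core and changes one group: hydroxy in place of trifluoromethyl on an aromatic carbon. Hydroxy itself has not yet been measured in this series, so the closest guide is what other swaps at this group did. Putting trifluoromethyl in place of methyl gave an at least 1.0-fold lower number from compound 1 to compound 3 (0.03 log units; that floor lies within the scatter). Putting it in place of dimethylamino gave an at least 1.0-fold lower number from compound 2 to compound 3 (0.03 log units; that floor lies within the scatter). The remaining swap gave a step that the two limits leave unreadable from compound 1 to compound 2.

With those two small readable steps as the guide, no change beyond the scatter is expected, and the expected move is a 1.1-fold higher number from compound 3 to compound 4 (0.04 log units; within the scatter). The estimate for compound 4 is 25000 nM, with an expected range from 11000 nM to 50000 nM.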

Compound 4, half-maximal effective concentration: > 25000 nM
Compound 4 gave a limit, no number (the forecaster's own chance of this, stated with the estimate: 55%); the middle value sits exactly at the limit.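

In this assay, placing hydroxy on this aromatic carbon, para to a large group, gives an at least 1.0-fold higher number from compound 3 to compound 4 (0.03 log units; that floor lies within the scatter). Hydroxy brings a hydrogen-bond donor and a hydrogen-bond acceptor where trifluoromethyl has neither, yet this exchange produces no readable change beyond the scatter. The steps to compound 4 from compound 1 and from compound 2 cannot be read, since both ends of each are limits, and most of the series now sits at one limit: the limit of > 25000 nM in this assay, at which 3 of the 4 values shown sit.

From the compounds shown here alone, how compound 1, compound 2 and compound 4 rank among themselves stays unknown, as none of them has an actual number. Also open, going by these compounds, is whether a carboxylic acid, a primary amine or a longer alkyl chain at this position would give a clearly lower number than those seen here.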